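Hydroxyl-to-chloro swap on the methylidene substituent of compound 1

This account rests on a few compounds, and the source may have more. Where it says the series, first, only, none or still open, it means among the compounds named here.

Measured compounds:
- compound 1 `COc1cc2c(/C=C3/C(=O)Nc4ccc(O)cc43)c(Cl)n(Cc3cc(OC)c(OC)c(OC)c3)c2cc1C`: 1410 nM
- compound 2 `COc1ccc2c(c1)/C(=C\c1c(Cl)n(Cc3cc(OC)c(OC)c(OC)c3)c3cc(C)c(OC)cc13)C(=O)N2`: 10200 nM
- compound 3 `COc1ccc2c(c1)/C(=C\c1c(OC)n(-c3ccccc3)c3ccccc13)C(=O)N2`: 630 nM

In a functional assay on cells (Cancer cell lines, Homo sapiens) for cytotoxicity, with a stated time of 48 h (a higher number here means a weaker inhibitor of growth, a lower number a stronger inhibitor of growth), compound 1 gives 1410 nM, the second highest of the three numbers; compound 3 gives 630 nM, a lower number beyond the scatter, and compound 2 gives 10200 nM, the highest. Compound 3 differs from compound 1 in several places, so its value says nothing about any single change.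

Compound 4 `COc1cc2c(/C=C3/C(=O)Nc4cccc(Cl)c43)c(Cl)n(Cc3cc(OC)c(OC)c(OC)c3)c2cc1C` differs from compound 1 in one place: a group of 12 heavy atoms (9 carbon, 1 nitrogen, 1 oxygen, 1 chlorine; one five-membered non-aromatic ring with 1 hetero atom, one six-membered aromatic ring of carbon only) in place of a group of 12 heavy atoms (9 carbon, 1 nitrogen, 2 oxygen; one five-membered non-aromatic ring with 1 hetero atom, one six-membered aromatic ring of carbon only), on an aromatic carbon. The group that leaves carries the hydroxyl of compound 1; the group that enters has a chlorine in its stead, and one donor and one acceptor fewer.

Within the data shown here, the only single-change step in hand bears directly on this: a 7.2-fold higher number from compound 1 to compound 2 (0.86 log units; beyond the scatter), where methylation of that same hydroxyl cost a modest amount of potency. Loss of the hydroxyl outright, with a chlorine entering the aromatic ring instead, is expected to go the same way, and a step of similar or somewhat smaller size is expected. Compound 4 is therefore estimated at 6000 nM (range 2000 nM to 18000 nM), corresponding to an expected step of a 4.3-fold higher number from compound 1 to compound 4 (0.63 log units; beyond the scatter).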

Compound 4, concentration for 50% growth inhibition: 2950 nM
Estimate against measurement, compound 4: 2.0-fold (0.31 log units) above; low and high end bracket the measured number.
By their numbers in this assay, from the lowest: compound 3; then compound 1; then compound 4; then compound 2.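

In this assay, the change from the hydroxyl-bearing group to the chlorine-bearing group gives a 2.1-fold higher number from compound 1 to compound 4 (0.32 log units; beyond the scatter) as its step, which is beyond the scatter but smaller than the step on methylation of the hydroxyl, a 7.2-fold higher number from compound 1 to compound 2 (0.86 log units; beyond the scatter), so the two changes at this part of the molecule do not cost the same. The hydroxyl is therefore not an absolute requirement for growth inhibition in this small set, since compound 4, with a chlorine in the entering group and fewer hydrogen-bond donors and acceptors, still gives a lower number than the methoxy compound 2 does from the same starting point, although compound 1 keeps the lowest number of the three. No measurement in hand accounts for the difference between these two steps.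

The compounds shown cannot separate the loss of the hydroxyl from the arrival of the chlorine, as both occur in the single step to compound 4. On these data alone, how an unsubstituted aromatic ring, an amine or a carboxylic acid would behave in the same setting remains open, as does whether the order of these steps holds on other cores.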